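Compound 4: Permeability Expected Close to Compound 3

A few compounds are considered here, and "the series" means these few. Any claim that something is new, unique, unknown or untested is made for them only; others in the source may bear on it.

Three compounds of this series have been run in an ADME assay for permeability, using PAMPA, with a stated time of 4 h; on this read-out lower numbers stand for lower permeability and higher numbers for higher permeability. Compound 1 `Cc1cc(C)cc(Oc2ccc3nc(COc4cccc(C(=O)O)c4)n(C)c3n2)c1` gives 17.4 10^-6 cm/s, compound 2 `Cn1c(COc2cccc(C(=O)O)c2)nc2ccc(Oc3ccc4c(c3)OCC4)nc21` gives 9.1 10^-6 cm/s, and compound 3 `Cn1c(COc2cccc(C(=O)O)c2)nc2ccc(Oc3cc(Cl)ccn3)cc21` gives 10.3 10^-6 cm/s. Compound 3 stands second among the three numbers, but its gap to compound 2 and its gap to compound 1 both lie within the scatter, so none of the three is separated from another. Within the data shown here, the only step between measured compounds that differ in a single place, a 1.9-fold lower number from compound 1 to compound 2 (0.28 log units; within the scatter), likewise falls within the scatter. Compound 4 `Cc1cc(F)cnc1Oc1ccc2nc(COc3cccc(C(=O)O)c3)n(C)c2c1` differs from compound 3 by 5-fluoro-3-methylpyridin-2-yl in place of 4-chloropyridin-2-yl on an oxygen on an aromatic ring. Among the measured compounds shown here, no measured step touches this position or these groups, so the data offer no pointer to a shift in either direction, and the one step seen is flat. Compound 3 at 10.3 10^-6 cm/s is therefore the anchor. The expected step is a 1.0-fold lower number from compound 3 to compound 4 (0.01 log units; within the scatter), within the scatter. Compound 4 is estimated at 10 10^-6 cm/s, with a range from 5 10^-6 cm/s to 20 10^-6 cm/s.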

Compound 4, apparent permeability: 8.3 10^-6 cm/s
For compound 4 the middle estimate is 1.2-fold (0.08 log units) above the measured one; the range from low to high includes it.
By their numbers in this assay, from the lowest: compounds 4, 2, 3 and 1 (each within the scatter of the next, the first and the last beyond it).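

In this assay, the change from (4-chloropyridin-2-yl)oxy to (5-fluoro-3-methylpyridin-2-yl)oxy gives a 1.2-fold lower number from compound 3 to compound 4 (0.09 log units; within the scatter) and is the first single change shown on this core between two pyridine groups on an oxygen on an aromatic ring. Exchanging the chlorine-bearing group for one that carries both a fluorine and a methyl therefore leaves compound 3 and compound 4 unseparated on this read-out. Nothing shown bears on why this step has the size it has.

From the compounds shown here alone, it remains open whether the fluorine or the methyl taken alone would give the same result, since the step changes both together. Going by these compounds, it is also open whether a group of another kind on this oxygen, such as an alkyl chain ending in an amine, would produce a step beyond the scatter.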